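This account rests on a few compounds, and the source may have more. Where it says the series, first, only, none or still open, it means among the compounds named here.

Compound 2 `CCCn1c(=O)c2nc(-c3ccc(F)cc3F)[nH]c2n(CCC)c1=O` gives 51 nM in an assay on isolated protein for binding affinity to adenosine receptor A1 (Rattus norvegicus); a lower number here means a stronger inhibitor, a higher number a weaker inhibitor. Of the two compounds measured it shows the lowest number; the nearest is compound 1 `CCCn1c(=O)c2nc(-c3cc(O)ccc3O)[nH]c2n(CCC)c1=O`, which in this assay gives 360 nM. Among the measured compounds shown here, the single step measured, a 7.1-fold lower number from compound 1 to compound 2 (0.85 log units; beyond the scatter), came with the exchange of a 2,5-dihydroxyphenyl for a 2,4-difluorophenyl on an aromatic carbon. Compound 3 `CCCn1c(=O)c2nc(-c3ccc(O)c(Cl)c3)[nH]c2n(CCC)c1=O` differs from compound 2 by 3-chloro-4-hydroxyphenyl in place of 2,4-difluorophenyl on an aromatic carbon. That step bears on it in reverse: the ring that enters carries a hydroxyl once more, this time together with a chlorine, and since compound 1 with its hydroxyl-bearing ring gives 360 nM, a move back toward a higher number is expected, though not necessarily all the way, as the entering group is not the one that left. The step is therefore expected to be a 2.9-fold higher number from compound 2 to compound 3 (0.47 log units; beyond the scatter). For compound 3 the estimate in this assay is 150 nM, with a range from 50 nM to 500 nM.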

Compound 3, inhibition constant: 36 nM
Compound 3: the middle estimate sits 4.2-fold (0.62 log units) above what was measured, outside the stated range (below it).
By their numbers in this assay, from the lowest: compounds 3 and 2 (each within the scatter of the next); then compound 1.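

The step of a 1.4-fold lower number from compound 2 to compound 3 (0.15 log units; within the scatter) shows that in this assay this position accepts 3-chloro-4-hydroxyphenyl and 2,4-difluorophenyl alike, although the first has one hydrogen-bond donor and the second none. A hydroxyl on this ring therefore does not by itself go with the higher number of compound 1, and the step of a 10-fold lower number from compound 1 to compound 3 (1.00 log units; beyond the scatter) shows that the two hydroxyl-bearing rings are far from interchangeable here. No evidence is available that explains this difference between them.

Going by these compounds, in compound 3 the chlorine and the hydroxyl enter together, so what each contributes stays open. Also open, on these data alone, is whether a hydroxyphenyl without the chlorine, or a phenyl ring carrying an amine or a carboxylic acid, would give a number nearer to that of compound 3 or of compound 1.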